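This account rests on a few compounds, and the source may have more. Where it says the series, first, only, none or still open, it means among the compounds named here.

Three members of the series have been run in a functional assay on ACHN cells (Homo sapiens) for inhibition, read by sulforhodamine B assay, with a stated time of 48 h (a lower number here means a stronger inhibitor of growth, a higher number a weaker inhibitor of growth), so far. Compound 1 `COc1cc(-c2cc(/C=C/C(=O)c3ccc(N)cc3)[nH]n2)cc(OC)c1OC` gives 1610 nM. Compound 2 `COc1ccc(C(=O)/C=C/c2cc(-c3cc(OC)c(OC)c(OC)c3)n[nH]2)cc1OC` gives 1660 nM, and compound 3 `COc1ccc(C(=O)/C=C/c2cc(-c3cc(OC)c(OC)c(OC)c3)n[nH]2)cc1` gives 1960 nM. The step from compound 1 to compound 2 is a 1.0-fold higher number from compound 1 to compound 2 (0.01 log units; within the scatter), the step from compound 1 to compound 3 is a 1.2-fold higher number from compound 1 to compound 3 (0.09 log units; within the scatter), and the step from compound 2 to compound 3 is a 1.2-fold higher number from compound 2 to compound 3 (0.07 log units; within the scatter); all three sit within the scatter of the method, so no order among the measured compounds can be claimed.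

Compound 4 `COc1ccc(-c2cc(/C=C/C(=O)c3ccc(N)cc3)[nH]n2)cc1OC` awaits measurement. It is related to compound 1 by hydrogen in place of methoxy on an aromatic carbon. The same kind of change connects compound 2 to compound 3, where it reads (hydrogen in place of methoxy on an aromatic carbon); the two places are not identical in their printed description, since in compound 1 the aromatic carbon in question is also meta to a methoxy group, whereas in compound 2 it is only ortho to a methoxy group and meta to a large group. The two cores differ as 4-aminophenyl in place of 3,4-dimethoxyphenyl on a carbonyl carbon. Within the measured pairs that change moved the number by a 1.2-fold higher number from compound 2 to compound 3 (0.07 log units; within the scatter), which is within the scatter.

On the basis of the step from compound 2 to compound 3 a 1.2-fold higher number from compound 2 to compound 3 (0.07 log units; within the scatter), the step from compound 1 to compound 4 is expected to be about a 1.2-fold higher number from compound 1 to compound 4 (0.08 log units; within the scatter). Compound 4 is therefore estimated at 1950 nM, with a range from 900 nM to 4200 nM.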

Compound 4, concentration for 50% growth inhibition: 1670 nM
The estimate for compound 4 lay 1.2-fold (0.07 log units) above the measured number; low and high end bracket the measured number.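

In this assay, hydrogen in place of methoxy on an aromatic carbon gives a 1.0-fold higher number from compound 1 to compound 4 (0.02 log units; within the scatter), so this step is no larger than the scatter of the method. Set beside the earlier case, the same change shows no difference between the two cores that the data can resolve: the same change on two cores in this assay, a 1.2-fold higher number (0.07 log units; within the scatter) from compound 2 to compound 3 and a 1.0-fold higher number (0.02 log units; within the scatter) from compound 1 to compound 4, 1.1-fold (0.06 log units) apart, within the scatter of two such steps This supports only a limited statement: on these two cores, the loss of this methoxy produces no readable shift, but because neither step rises above the scatter, the agreement does not show that a real effect of any particular size carries from one core to the other, and two cores do not establish a rule for the wider series.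

The compounds shown leave open whether any group other than methoxy or hydrogen at this place, such as a hydroxyl, a fluorine or a longer alkoxy chain like ethoxy, would give a step beyond the scatter. Also open, going by these compounds, is what a dimethylamino group or a carboxylic acid would give in place of the amino group of compound 4, and whether the close agreement of these steps would hold on a further core.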